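Ether substituent variation in the shared core series

The source may report more compounds than this note shows. Statements on the series, on what has been measured and on what is new or still open speak of the compounds shown alone.

Measured compounds in a functional assay on L1210 cells (Mus musculus) for antiproliferative activity, read by cell counting, with a stated time of 96 h; a higher number here means a weaker inhibitor, a lower number a stronger inhibitor:
compound 1 `CC(Nc1ccccc1Oc1cccc(F)c1)=C1C(=O)CC(c2ccccc2)CC1=O`, 330 nM
compound 2 `CC(Nc1ccccc1Oc1ccc(N)cc1)=C1C(=O)CC(c2ccccc2)CC1=O`, 40 nM
compound 3 `CCOc1ccccc1NC(C)=C1C(=O)CC(c2ccccc2)CC1=O`, 190 nM

Compound 1 gives the highest number of the three in this assay; compound 3 lies within the scatter of it (a 1.7-fold lower number from compound 1 to compound 3 (0.24 log units; within the scatter)), whereas compound 2 lies clearly lower (an 8.3-fold lower number from compound 1 to compound 2 (0.92 log units; beyond the scatter)). Compound 4 `COc1ccc(Oc2ccccc2NC(C)=C2C(=O)CC(c3ccccc3)CC2=O)cc1OC` differs from compound 1 by 3,4-dimethoxyphenyl in place of 3-fluorophenyl on an oxygen on an aromatic ring. Among the compounds with values here, two steps bear on this change: the ethyl replacement, a 1.7-fold lower number from compound 1 to compound 3 (0.24 log units; within the scatter), which changed little, and the 4-aminophenyl replacement, an 8.3-fold lower number from compound 1 to compound 2 (0.92 log units; beyond the scatter), which lowered the number modestly. Compound 4 keeps a substituted phenyl on the oxygen, as compound 2 does, so a modest lowering is expected, likely smaller than the step to compound 2, with a 2.5-fold lower number from compound 1 to compound 4 (0.40 log units; beyond the scatter) as the expected step. Compound 4 is estimated at 130 nM in this assay, between 45 nM and 400 nM.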

Compound 4, half-maximal inhibitory concentration: 65 nM
Compound 4: middle estimate off by 2.0-fold (0.30 log units), on the high side, within the range that was stated.
By their numbers in this assay, from the lowest: compounds 2 and 4 (each within the scatter of the next); then compounds 3 and 1 (each within the scatter of the next).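

Within the data shown here, in (this assay), 3,4-dimethoxyphenyl on the oxygen gives a clear gain over 3-fluorophenyl (a 5.1-fold lower number from compound 1 to compound 4 (0.71 log units; beyond the scatter)) and over ethyl (a 2.9-fold lower number from compound 3 to compound 4 (0.47 log units; beyond the scatter)), so 4-aminophenyl is no longer the only aryl group to do so. Compound 1 remains the exception, since its 3-fluorophenyl does not separate from ethyl. The amino group is also not required for a low number, as the gap to the 4-aminophenyl compound stays small (a 1.6-fold higher number from compound 2 to compound 4 (0.21 log units; within the scatter)).

Nothing at hand gives a cause for these steps. From the compounds shown here alone, whether one methoxy group alone, as in 4-methoxyphenyl, or a 4-hydroxyphenyl would hold this level remains open.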